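From nitro to amino: what to expect for compound 4

The compounds below may be only part of what the source reports. "The series", "measured", "known", "first", "only" and "open" are said of these compounds alone.

Measured in a functional assay on K562 cells (Homo sapiens) for antiproliferative activity, read by CellTiter-Glo and CCK-8 assay, with a stated time of 72 h (on this read-out lower numbers stand for stronger inhibition of growth and higher numbers for weaker inhibition of growth), as follows
- Compound 1 `CNc1nc(Nc2ccc(C)c([N+](=O)[O-])c2)ncc1C(=O)Nc1cc(NC(=O)c2cccc(C(F)(F)F)c2)ccc1C` gives 52 nM
- Compound 2 `Cc1ccc(NC(=O)c2cccc(C(F)(F)F)c2)cc1NC(=O)c1cnc(Nc2ccc(C)c([N+](=O)[O-])c2)nc1N(C)C` gives > 10000 nM (a limit of the assay, not a number)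
- Compound 3 `Cc1ccc(NC(=O)c2cccc(C(F)(F)F)c2)cc1NC(=O)c1cnc(Nc2ccc(C)c([N+](=O)[O-])c2)nc1` gives 380 nM

Of the two actual numbers, compound 3 holds the higher, with a 7.3-fold higher number from compound 1 to compound 3 (0.86 log units; beyond the scatter) setting it apart. Compound 4 `Cc1ccc(Nc2ncc(C(=O)Nc3cc(NC(=O)c4cccc(C(F)(F)F)c4)ccc3C)cn2)cc1N` carries amino in place of nitro on an aromatic carbon and is otherwise unchanged. Among the compounds with values here, no measured step touches this position. Within the data shown here, the steps of an at least 190-fold higher number from compound 1 to compound 2 (2.28 log units; beyond the scatter) and an at least 26-fold lower number from compound 2 to compound 3 (1.42 log units; beyond the scatter), like the one above, concern a different group, and they show only that single changes can range from modest to large. A modest move towards a higher number is therefore expected, though a result within the scatter remains possible. The expected change is a 1.8-fold higher number from compound 3 to compound 4 (0.27 log units; within the scatter) and is only loosely grounded. For compound 4 the estimate is 700 nM, with an expected range from 150 nM to 3500 nM in this assay.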

Compound 4, concentration for 50% growth inhibition: 330 nM
Compound 4: the middle estimate sits 2.1-fold (0.33 log units) above what was measured; the measured number falls inside the stated range.
By their numbers in this assay, from the lowest: compound 1; then compounds 4 and 3 (each within the scatter of the next). At a limit, above all of these: compound 2.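

Within the data shown here, this is the only measured change at this position: going from 4-methyl-3-nitrophenyl to 3-amino-4-methylphenyl gives a 1.2-fold lower number from compound 3 to compound 4 (0.06 log units; within the scatter). In this assay, nitro and amino therefore read alike here on the shared core, unlike the large step seen when dimethylamino replaces methylamino elsewhere. Nothing shown speaks to why the two groups read alike. On these data alone, whether an acetamide or a hydroxyl at this position would read the same remains open. So does whether amino here would match nitro with methylamino on the core, as in compound 1.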